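Sulfonyl group exchange from compound 2 to compound 3

This account rests on a few compounds, and the source may have more. Where it says the series, first, only, none or still open, it means among the compounds named here.

Measured so far:
compound 1 `COc1ccc(S(=O)(=O)N2CC(C(=O)N3CC(CN)C3)c3ccccc32)c2ccccc12` — 79.4 nM
compound 2 `CN1CCC(N(C)C(=O)C2CN(S(=O)(=O)c3cccc4c(Cl)cccc34)c3ccccc32)CC1` — 5.01 nM

Both numbers come from a functional assay on CHO cells for antagonist activity at 5-hydroxytryptamine receptor 6 (Homo sapiens), read by FLIPR; a higher number here means a weaker inhibitor, a lower number a stronger inhibitor. Compound 2 gives the lower of the two numbers; its nearest neighbour, compound 1, sits well above it, a gap beyond the usual scatter. Compound 1 and compound 2 differ in more than one place, so no single change accounts for the gap between them.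

Compound 3 `CN1CCC(N(C)C(=O)C2CN(S(=O)(=O)C3=CC4CCOC4C=C3)c3ccccc32)CC1` is not yet measured. Compared with compound 2, it carries a group of 9 heavy atoms (8 carbon, 1 oxygen; one five-membered non-aromatic ring with 1 hetero atom, one six-membered non-aromatic ring of carbon only) in place of a group of 11 heavy atoms (10 carbon, 1 chlorine; 2 six-membered aromatic rings of carbon only), on a sulfonyl sulfur. Within the data shown here, no pair of measured compounds separated by a single change of this kind is available, so the step has to be judged from the change alone: two aromatic rings and a chlorine give way to two non-aromatic rings with one oxygen. A step toward weaker inhibition in this assay is expected, of moderate size and probably beyond the scatter, though the direction is not secure. The expected step is a 5.0-fold higher number from compound 2 to compound 3 (0.70 log units; beyond the scatter). Compound 3 is estimated at 25 nM, with a range of 6 nM to 120 nM.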

Compound 3, inhibition constant: 31.6 nM
Compound 3: the middle estimate sits 1.3-fold (0.10 log units) below what was measured; measured number inside the range.
By their numbers in this assay, from the lowest: compound 2; then compound 3; then compound 1.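

In this assay, among these compounds, this is the first single-change reading on the sulfonyl sulfur: replacing the 5-chloronaphthalen-1-yl group with the oxygen-bearing non-aromatic bicyclic group gives a 6.3-fold higher number from compound 2 to compound 3 (0.80 log units; beyond the scatter), a loss beyond the scatter. Even so, compound 3 gives 31.6 nM as a measured inhibitor, so neither aromatic rings nor chlorine on this sulfonyl group are needed for inhibition in the nanomolar range, although the 5-chloronaphthalen-1-yl group gives the lower number of the two. No supporting measurement bears on the size of this step, so the result describes the change without explaining it.

The exchange alters the rings, the chlorine and the oxygen in one step, so the compounds shown do not assign the loss to any one of them. A naphthalen-1-yl group without chlorine would separate the chlorine from the ring system, and a fully saturated bicyclic ether would test whether the double bonds outside aromatic rings in compound 3 matter at this place.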